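The source may report more compounds than this note shows. Statements on the series, on what has been measured and on what is new or still open speak of the compounds shown alone.

Measured compounds:
- compound 1, `COc1ccc(C(=O)/C=C/c2cc(-c3cc(OC)c(OC)c(OC)c3)n[nH]2)cc1OC`: -86%
- compound 2, `COc1ccc(C(=O)/C=C/c2cc(-c3cc(OC)c(OC)c(OC)c3)n[nH]2)cc1`: 7%

In a functional assay on SN12C cells (Homo sapiens) for cytotoxicity, read by sulforhodamine B assay, with a stated time of 48 h, tested at 100 uM (on this read-out higher numbers stand for a weaker effect at the one concentration tested and lower numbers for a stronger effect), compound 1 gives -86% and compound 2 gives 7%. Going by the values given here, compound 2 holds the higher of the two values, the weaker read-out, and the only measured step, a number 93 percentage points higher from compound 1 to compound 2 (beyond the scatter), is the one that separates it from compound 1.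

Compound 3, `COc1cc(-c2cc(/C=C/C(=O)c3ccc(F)c(F)c3)[nH]n2)cc(OC)c1OC`, is not yet measured. It differs from compound 2 as follows: 3,4-difluorophenyl in place of 4-methoxyphenyl on a carbonyl carbon. Among the compounds with values here, no measured step covers this exchange of one aryl group for another. Within the data shown here, the one step on record, a number 93 percentage points higher from compound 1 to compound 2 (beyond the scatter), touches the same aryl group on the carbonyl carbon and shows that a change there can move the read-out well beyond the scatter. Whether the 3,4-difluorophenyl behaves more like the 4-methoxyphenyl of compound 2 or like the 3,4-dimethoxyphenyl of compound 1 cannot be read from these two values; the direction of a number 2 percentage points lower from compound 2 to compound 3 (within the scatter) is therefore expected to be uncertain, with a wide range. The estimate for compound 3 in this assay is 5%, spanning -45% to 40%.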

Compound 3, a percentage reported as activity, at one concentration (the size of the read-out at that concentration, not a potency): -22%
Compound 3: middle estimate off by 27 percentage points, on the high side, within the range that was stated.
By their numbers in this assay, from the lowest: compound 1; then compound 3; then compound 2.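

In this assay, the aryl group on the carbonyl carbon now has three forms, all separated beyond the scatter: a number 29 percentage points lower from compound 2 to compound 3 (beyond the scatter), and a number 64 percentage points higher from compound 1 to compound 3 (beyond the scatter). A stronger read-out at this place therefore does not depend on methoxy groups, since 3,4-difluorophenyl, with no hydrogen-bond acceptor, gives a stronger read-out than 4-methoxyphenyl, though a weaker one than 3,4-dimethoxyphenyl; among these three compounds, 3,4-dimethoxyphenyl in compound 1 and 3,4-difluorophenyl in compound 3 both give lower numbers than 4-methoxyphenyl in compound 2, and none of the three goes against that pattern. Nothing in hand explains this order of the three groups.

Open, on these data alone, is whether 4-fluorophenyl or 3,4-dichlorophenyl on the carbonyl carbon would fall with compound 2 or with compound 3, which would show whether the pattern holds beyond these three groups. Also open, as far as these compounds go, is how a more distant replacement at this place, such as a pyridine ring or a phenyl carrying an amine or a carboxylic acid, would read out against the shared core.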